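Replacing the aryl ketone substituent in a stilbene-chalcone series

The compounds below may be only part of what the source reports. "The series", "measured", "known", "first", "only" and "open" are said of these compounds alone.

Of the compounds shown here, three sharing one core have been measured in a functional assay on A549 cells (Homo sapiens) for antiproliferative activity, read by MTT assay, with a stated time of 48 h; a higher number here means a weaker inhibitor, a lower number a stronger inhibitor. Compound 1 `CCCCOc1ccc(C(=O)/C=C/c2c(/C=C/c3ccc(OC)cc3)cc(OC)cc2OC)cc1` gives 8.7 ug/mL. Compound 2 `CCOc1ccc(C(=O)/C=C/c2c(/C=C/c3ccc(OC)cc3)cc(OC)cc2OC)cc1` gives 7.5 ug/mL, and compound 3 `COc1ccc(/C=C/c2cc(OC)cc(OC)c2/C=C/C(=O)c2ccc(C(F)(F)F)cc2)cc1` gives 7.8 ug/mL. Compound 3 stands within the scatter of both others: the step of a 1.1-fold lower number from compound 1 to compound 3 (0.05 log units; within the scatter) and the step of a 1.0-fold higher number from compound 2 to compound 3 (0.02 log units; within the scatter) are both small, as is the step of a 1.2-fold lower number from compound 1 to compound 2 (0.06 log units; within the scatter) between the two alkoxy analogues. Every change so far has been made on the aryl ring attached to the carbonyl, and none has moved the number beyond the scatter.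

Compound 4 `COc1ccc(/C=C/c2cc(OC)cc(OC)c2/C=C/C(=O)c2ccccc2C)cc1` continues on that same ring with a different group: 2-methylphenyl in place of 4-(trifluoromethyl)phenyl on a carbonyl carbon. For the measured compounds named here, no measured pair tests this particular exchange, so the expectation rests on the three steps above, which together suggest that the ketone aryl ring tolerates substituent changes without a shift in this assay. It is therefore expected that compound 4 shows a 1.0-fold higher number from compound 3 to compound 4 (0.01 log units; within the scatter), that is, no step beyond the scatter. Compound 4 is estimated at 8 ug/mL, with a likely range from 4 ug/mL to 16 ug/mL.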

Compound 4, half-maximal inhibitory concentration: 5.9 ug/mL
The estimate for compound 4 lay 1.4-fold (0.13 log units) above the measured number, and the stated range covers the measured number.
By their numbers in this assay, from the lowest: compounds 4, 2, 3 and 1 (each within the scatter of the next).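

For the compounds shown here, compound 4 is the first in the set whose group on the carbonyl carbon is not a 4-substituted phenyl, so both the substituent and its place on the ring differ from the earlier compounds. Even so, in this assay the exchange of 2-methylphenyl for the three earlier groups gives a 1.3-fold lower number from compound 3 to compound 4 (0.12 log units; within the scatter), a 1.3-fold lower number from compound 2 to compound 4 (0.10 log units; within the scatter) and a 1.5-fold lower number from compound 1 to compound 4 (0.17 log units; within the scatter), so the tolerance seen among the 4-substituted rings now extends to a smaller group without fluorine, and no step among the four compounds goes beyond the scatter. Nothing available explains the small differences in these numbers or shows what the cells respond to in this series.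

The compounds shown do not separate the identity of a group from its place on this ring, since methyl appears at only one place and each alkoxy chain and the trifluoromethyl at another. As far as these compounds go, whether an amine or a carboxylic acid on this ring would move the number beyond the scatter remains open, as does the effect of changing the methoxy groups on the shared core, which are the same in all four compounds.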